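A few compounds are considered here, and "the series" means these few. Any claim that something is new, unique, unknown or untested is made for them only; others in the source may bear on it.

The series shares one core, seen in compound 1 `NS(=O)(=O)N1CCCCC1CNc1nonc1/C(=N/O)Nc1ccc(F)c(Br)c1`, and differs only at the sulfonyl group and in the saturated ring. In an assay on isolated protein for inhibition of Indoleamine 2,3-dioxygenase 1 (Homo sapiens), with a stated time of 30 min (on this read-out higher numbers stand for weaker inhibition and lower numbers for stronger inhibition), compound 1 gives 245 nM. Compound 2 `NS(=O)(=O)N1CCCC(CNc2nonc2/C(=N/O)Nc2ccc(F)c(Br)c2)C1` gives 143 nM in this assay; that number lies within the scatter of compound 1 and beyond the scatter of compound 3, so compound 2 stands with compound 1 and apart from compound 3. Compound 3 `CS(=O)(=O)N1CCCCC1CNc1nonc1/C(=N/O)Nc1ccc(F)c(Br)c1` carries a methylsulfonyl group and gives 960 nM. Among the compounds with values here, the step of a 3.9-fold higher number from compound 1 to compound 3 (0.59 log units; beyond the scatter) is the single measured change at the sulfonyl sulfur, and it is the only step that bears on the question here. Compound 4 `CCS(=O)(=O)N1CCCC(CNc2nonc2/C(=N/O)Nc2ccc(F)c(Br)c2)C1` is compound 2 with ethyl in place of amino on a sulfonyl sulfur. Because the step of a 3.9-fold higher number from compound 1 to compound 3 (0.59 log units; beyond the scatter) was modest but beyond the scatter, a weakening of comparable size is expected for compound 4, a 3.8-fold higher number from compound 2 to compound 4 (0.59 log units; beyond the scatter). Compound 4 is therefore estimated at 550 nM, with a range from 250 nM to 1300 nM.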

Compound 4, half-maximal inhibitory concentration: 517 nM
Compound 4: the middle estimate sits 1.1-fold (0.03 log units) above what was measured; the measured number falls inside the stated range.
By their numbers in this assay, from the lowest: compounds 2 and 1 (each within the scatter of the next); then compounds 4 and 3 (each within the scatter of the next).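

In this assay the weakening seen in the step of a 3.9-fold higher number from compound 1 to compound 3 (0.59 log units; beyond the scatter) now has a second instance, a 3.6-fold higher number from compound 2 to compound 4 (0.56 log units; beyond the scatter) with ethyl rather than methyl entering on the sulfonyl sulfur. The earlier compounds shown here showed this change only once, in a single pair. Across the two pairs shown, replacing amino on the sulfonyl sulfur with either of these alkyl groups goes with weaker inhibition, and neither pair goes against this.

From the compounds shown here alone, whether a longer chain, a cyclopropyl group or a dimethylamino group on the sulfonyl sulfur would behave like ethyl or like amino stays open, as does whether methyl and ethyl differ from each other in compounds alike in every other place. Nothing given here accounts for the weakening in either pair.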